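The source may hold more compounds than are shown below. What is called first, only, known or untested is meant among the compounds shown, and "the series" means these compounds.

In a functional assay on MCF7 cells (Homo sapiens) for antiproliferative activity, read by MTT assay (on this read-out higher numbers stand for weaker inhibition and lower numbers for stronger inhibition), compound 1 `CCCCCCCCCCCCCCCC1(O)CC(=O)c2c(O)cc(O)cc2O1` gives 17500 nM, and compound 3 `CCCCC/C=C\C/C=C\CCCCCCCc1cc(=O)c2c(O)cc(O)c(C)c2o1` gives 17500 nM. Compound 2 `CCCCC/C=C\C/C=C\CCCCCCCc1cc(=O)c2c(O)c(C)c(OCOC)c(C)c2o1` is recorded at > 84100 nM, which is a limit and not a number. Its standing among the three results is the limit of > 84100 nM in this assay, at which 1 of the 3 values shown sits.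

Compound 4 `CCCC/C=C\CCCCCCCCCc1cc(=O)c2c(O)c(C)c(OCOC)c(C)c2o1` differs from compound 2 as follows: oct-3-en-1-yl in place of deca-1,4-dien-1-yl on a saturated chain carbon, seven bonds along the chain from an aromatic carbon. In words, oct-3-en-1-yl stands in place of deca-1,4-dien-1-yl on a saturated chain carbon, seven bonds along the chain from an aromatic carbon.

Among the measured compounds shown here, no measured pair isolates this chain change, so no shift beyond the scatter is expected in this assay, and compound 4 may also be reported only as a limit. The expected step that the limit leaves unreadable from compound 2 to compound 4 stays within the usual scatter. For compound 4 the estimated value is 85000 nM, with an expected range from 40000 nM to 170000 nM.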

Compound 4, half-maximal inhibitory concentration: > 67200 nM
Compound 4: a limit, no number; the forecaster's own chance of this, stated with the estimate: 65%; the middle value lies beyond the limit too.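

In this assay compound 4 gives > 67200 nM, which is a limit and not a number. Among the compounds shown here, compound 2 gives > 84100 nM, also a limit, so no step between these two compounds can be read. The compounds shown leave open whether oct-3-en-1-yl in place of deca-1,4-dien-1-yl changes activity at all.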